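The source may hold more compounds than are shown below. What is called first, only, known or untested is meant among the compounds shown, and "the series" means these compounds.

Values in an ADME assay on microsomes from liver (Mus musculus) for metabolic stability; a higher number here means that the compound lasts longer, a lower number that the compound disappears faster:
compound 1 `CC(C)C(c1ccc(-c2ccc3cccc(F)c3c2)[nH]c1=O)N1CCCCC1=O`: 0.0967 h
compound 2 `Cc1nc(C(c2ccc(-c3ccc4cccc(F)c4c3)[nH]c2=O)C(C)C)[nH]c1C`: 0.0817 h
compound 3 `CC(C)C(c1ncc[nH]1)c1ccc(-c2ccc3cccc(F)c3c2)[nH]c1=O`: < 0.0667 h, a limit of the assay and not a number

Among the measured compounds shown here, compound 3 is the one compound of the three that sits at the limit of < 0.0667 h in this assay, at which 1 of the 3 values shown sits, so for compound 3 only a ceiling is known in this assay. Compound 4 `CC(C)NC(=O)CC(c1ccc(-c2ccc3cccc(F)c3c2)[nH]c1=O)C(C)C` differs from compound 3 in one place: (isopropylcarbamoyl)methyl in place of 1H-imidazol-2-yl on a saturated chain carbon bound to an aromatic carbon and a saturated chain carbon.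

For the measured compounds named here, no measured step exchanges an imidazolyl for an acyclic amide chain, so none bears directly on this change. Going by the values given here, the two steps that end in compound 3, an at least 1.4-fold lower number from compound 1 to compound 3 (0.16 log units; that floor lies within the scatter) and an at least 1.2-fold lower number from compound 2 to compound 3 (0.08 log units; that floor lies within the scatter), both carry a floor within the scatter; they show only that the three measured compounds lie close together with compound 3 at the limit. Compound 4 carries an amide, as compound 1 does in its 2-oxopiperidin-1-yl, and compound 1 gives 0.0967 h. A step of an at least 1.2-fold higher number from compound 3 to compound 4 (0.10 log units; that floor lies within the scatter) is therefore expected in this assay, upward but not beyond the scatter. Compound 4 is estimated at 0.085 h, with a range from 0.05 h to 0.17 h.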

Compound 4, half-life: < 0.0667 h
Compound 4: no number, only a limit; the forecaster's own chance of this, stated with the estimate: 35%; middle value at least 1.2-fold (0.10 log units) away from the limit.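

Compound 4 joins compound 3 at the assay limit in this assay, and this is a limit and not a number: the limit of < 0.0667 h in this assay, at which 2 of the 4 values shown sit. The step between these two compounds cannot be read. The readable steps, an at least 1.4-fold lower number from compound 1 to compound 4 (0.16 log units; that floor lies within the scatter) and an at least 1.2-fold lower number from compound 2 to compound 4 (0.08 log units; that floor lies within the scatter), show that the acyclic amide chain (isopropylcarbamoyl)methyl on this saturated chain carbon is not separated beyond the scatter from either 2-oxopiperidin-1-yl or 4,5-dimethyl-1H-imidazol-2-yl.

From the compounds shown here alone, whether any group at this place can move the half-life clear of the scatter remains open, for example a carboxylic acid or a tertiary amine on the same carbon. Also open, going by these compounds, is where compound 3 and compound 4 actually lie relative to each other, since neither has a number.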